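Compound 4 and the loss of the carbonyl group

This account rests on a few compounds, and the source may have more. Where it says the series, first, only, none or still open, it means among the compounds named here.

Measured so far in a functional assay on isolated protein for agonist activity at Glucose-dependent insulinotropic receptor (Rattus norvegicus), read by HTRF and cAMP accumulation; a higher number here means a larger maximal response, a lower number a smaller maximal response:
compound 1 `CC1(OC(=O)N2CCC(O[C@H]3CC[C@H](Oc4cnc(S(C)(=O)=O)cn4)CC3)CC2)CC1` with 123%
compound 2 `CS(=O)(=O)c1cnc(O[C@H]2CC[C@H](OC3CCN(C(=O)Oc4ccccc4)CC3)CC2)cn1` with 104%
compound 3 `CS(=O)(=O)c1cnc(O[C@H]2CC[C@H](OC3CCN(C(=O)C4(C(F)(F)F)CCCC4)CC3)CC2)cn1` with 124%

Among these three, compound 3 gives the highest number, though its gap to compound 1 is within the scatter, while its gap to compound 2 is beyond it: a number 20 percentage points higher from compound 2 to compound 3 (beyond the scatter). The two changes that lead to compound 3 are a number 1 percentage points higher from compound 1 to compound 3 (within the scatter) and a number 20 percentage points higher from compound 2 to compound 3 (beyond the scatter), both on the carbonyl carbon, and the third change, a number 19 percentage points lower from compound 1 to compound 2 (beyond the scatter), also keeps the carbonyl in place.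

Compound 4 `CS(=O)(=O)c1cnc(O[C@H]2CC[C@H](OC3CCN(CC4(C(F)(F)F)CC4)CC3)CC2)cn1` differs from compound 3 in another way: a group of 8 heavy atoms (5 carbon, 3 fluorine; one three-membered non-aromatic ring of carbon only) in place of a group of 11 heavy atoms (7 carbon, 1 oxygen, 3 fluorine; one five-membered non-aromatic ring of carbon only), on an amine nitrogen in a ring. Going by the values given here, no measured step touches the carbonyl itself, so there is nothing in the data that speaks directly to this change. What the three measured compounds show is that the maximal response has stayed in a band from compound 2 to compound 3 across different groups on the ring nitrogen. Compound 4 is therefore expected to land near that band, with a step of a number 12 percentage points lower from compound 3 to compound 4 (beyond the scatter) that may or may not exceed the scatter. For compound 4 the estimated value in this assay is 112%, between 88% and 135%.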

Compound 4, largest response reached (Emax), in percent of the reference or control that the assay uses: 124%
Compound 4: the middle estimate sits 12 percentage points below what was measured, and the stated range covers the measured number.
By their numbers in this assay, from the lowest: compound 2; then compounds 1, 3 and 4 (each within the scatter of the next).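

In this assay, the carbonyl on the amine nitrogen in a ring proves not to be needed for a response of this size: with (1-(trifluoromethyl)cyclopropyl)methyl on that nitrogen there is no change at the digits printed from compound 3 to compound 4 (within the scatter), and likewise a number 1 percentage points higher from compound 1 to compound 4 (within the scatter). The same group gives a number 20 percentage points higher from compound 2 to compound 4 (beyond the scatter), so among the four groups on this nitrogen, a group without a carbonyl matches the two best carbonyl-bearing ones, and phenoxycarbonyl alone stands apart. No measurement shown here explains why groups this different give matching maximal responses.

What the compounds leave open is how little this nitrogen can carry, since neither a free secondary amine nor a plain ethyl or benzyl group appears among them, and the trifluoromethyl and the cyclopropane ring of the new group are never varied separately. The maximal response also says nothing about the concentration at which each compound reaches it, so compounds with matching values here may still differ in potency.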